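A few compounds are considered here, and "the series" means these few. Any claim that something is new, unique, unknown or untested is made for them only; others in the source may bear on it.

Working notes on the series, read in a functional assay on HCT-116 cells (Homo sapiens) for antiproliferative activity, read by MTT assay, with a stated time of 72 h; a higher number here means a weaker inhibitor, a lower number a stronger inhibitor. Compound 1 `C=CC(=O)Nc1scc(-c2ccccc2)c1C(=O)OCC` reads > 30000 nM, which is a limit of the assay and not a number. Compound 2 `C=CC(=O)Nc1nc(-c2ccccc2Cl)cs1` gives 12300 nM and compound 3 `C=CC(=O)Nc1nc(-c2cccc(Cl)c2)cs1` gives 11900 nM. Among the measured compounds shown here, these two values lie within the scatter of each other, so compound 2 stands level with compound 3, and together they are the only numbers in hand.

The next structure is compound 4 `C=CC(=O)Nc1nc(-c2ccccc2F)cs1`, which departs from compound 2 by one swap: fluoro in place of chloro on an aromatic carbon. In words, this is fluoro in place of chloro on an aromatic carbon, ortho to a large group.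

For the measured compounds named here, no measured pair shows a swap of this kind, so the size of the step cannot be read from the data. The expectation therefore rests on compound 2 at 12300 nM as the closest measured structure. No step beyond the scatter is expected in this assay, with only a slight lean towards a higher number. The estimated change is a 1.1-fold higher number from compound 2 to compound 4 (0.06 log units; within the scatter). For compound 4 the expected value is 14000 nM, with an estimated range from 7000 nM to 28000 nM.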

Compound 4, half-maximal inhibitory concentration: 20400 nM
For compound 4 the middle estimate is 1.5-fold (0.16 log units) below the measured one, and the stated range covers the measured number.
By their numbers in this assay, from the lowest: compounds 3, 2 and 4 (each within the scatter of the next). At a limit, above all of these: compound 1.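

In this assay, among the compounds shown here, this is the first step read at this position, and it sets fluoro in place of chloro on an aromatic carbon, ortho to a large group, against a measured pair: a 1.7-fold higher number from compound 2 to compound 4 (0.22 log units; within the scatter). The step stays within the scatter, so this pair supports no ranking of chloro against fluoro at this place, and compound 2 and compound 4 stand level on the present data, though this is a single pair and says nothing about the same swap elsewhere on the ring. Compound 1 gives a limit and not a number, so it enters no step, and the series can only be read under that limit: the limit of > 30000 nM in this assay, at which 1 of the 4 values shown sits.

From the compounds shown here alone, whether anything other than a halogen at this place, such as methoxy, an amine or a carboxylic acid, would move the number beyond the scatter remains open. Also open is how the series would read with a saturated propanoyl amide in place of the acryloyl group, since every compound shown carries that group unchanged.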